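A few compounds are considered here, and "the series" means these few. Any claim that something is new, unique, unknown or untested is made for them only; others in the source may bear on it.

Measured so far in a functional assay on CHO cells for antagonist activity at prostaglandin E2 receptor EP3 subtype (Homo sapiens), read by cAMP accumulation; a lower number here means a stronger inhibitor, a higher number a weaker inhibitor:

Compound 1 `CC(C)C(c1ccc(-c2ccc3cccc(F)c3c2)[nH]c1=O)N1CCCCS1(=O)=O` gives 122 nM.
Compound 2 `CC(C)C(Nc1nccs1)c1ccc(-c2ccc3cccc(F)c3c2)[nH]c1=O` gives 10 nM.
Compound 3 `CC(C)C(Cc1noc(=O)[nH]1)c1ccc(-c2ccc3cccc(F)c3c2)[nH]c1=O` gives 70 nM.

Compound 3 stands second highest of the three numbers. Among the measured compounds shown here, its nearest neighbour is compound 1, and that pair is within the scatter; the one clearly separated compound is compound 2, as the step of a 7.0-fold higher number from compound 2 to compound 3 (0.85 log units; beyond the scatter) shows.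

Compound 4 `Cc1c[nH]c(C(c2ccc(-c3ccc4cccc(F)c4c3)[nH]c2=O)C(C)C)n1` is the next candidate. Relative to compound 3 the change is a group of 6 heavy atoms (4 carbon, 2 nitrogen; one five-membered aromatic ring with 2 hetero atoms) in place of a group of 7 heavy atoms (3 carbon, 2 nitrogen, 2 oxygen; one five-membered aromatic ring with 3 hetero atoms), on a saturated chain carbon bound to an aromatic carbon and a saturated chain carbon. For the measured compounds named here, the only measured steps at the same place are a 12-fold lower number from compound 1 to compound 2 (1.09 log units; beyond the scatter) and a 7.0-fold higher number from compound 2 to compound 3 (0.85 log units; beyond the scatter); the third, a 1.7-fold lower number from compound 1 to compound 3 (0.24 log units; within the scatter), is within the scatter. Both of the clear steps point the same way: the five-membered aromatic ring with 2 hetero atoms in compound 2 gave the lowest number of the three, and leaving it for either of the other groups raised the number. The group entering in compound 4 is again a five-membered aromatic ring with 2 hetero atoms, though without the nitrogen linker of compound 2, so the step is expected to fall between the two clear steps in size.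

A lower number beyond the scatter is therefore expected for compound 4, with the step of a 3.5-fold lower number from compound 3 to compound 4 (0.54 log units; beyond the scatter). In this assay compound 4 is estimated at 20 nM, within a range of 6 nM to 65 nM.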

Compound 4, half-maximal inhibitory concentration: 36 nM
Estimate against measurement, compound 4: 1.8-fold (0.26 log units) below; low and high end bracket the measured number.
By their numbers in this assay, from the lowest: compound 2; then compounds 4, 3 and 1 (each within the scatter of the next, the first and the last beyond it).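

In this assay, 4-methyl-1H-imidazol-2-yl on this saturated chain carbon cannot be told apart from the group it replaces (a 1.9-fold lower number from compound 3 to compound 4 (0.29 log units; within the scatter)), so exchanging one five-membered aromatic ring for the other at this place gives no readable change. The new group nevertheless stands clear of both ends of the series: (1,3-thiazol-2-yl)amino retains a margin over it (a 3.6-fold higher number from compound 2 to compound 4 (0.56 log units; beyond the scatter)), and it retains a margin over the six-membered non-aromatic ring of compound 1 (a 3.4-fold lower number from compound 1 to compound 4 (0.53 log units; beyond the scatter)), which shows that a five-membered aromatic ring with 2 hetero atoms does not by itself reproduce the number of compound 2, while compound 3, within the scatter of compound 1, keeps any ring-type trend from holding across all four compounds. Nothing available accounts for these differences.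

The compounds shown leave open whether the amino link or the thiazole ring sets compound 2 apart, a question that 1,3-thiazol-2-yl attached directly to the chain carbon and (1H-imidazol-2-yl)amino would address. On these data alone, the contribution of the methyl on the imidazole also remains open, as does the outcome of a carboxylic acid at this place.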